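Aryl substituent variation on a quinolone carboxamide core

A few compounds are considered here, and "the series" means these few. Any claim that something is new, unique, unknown or untested is made for them only; others in the source may bear on it.

Measured compounds:
compound 1, `O=C(Nc1ccc(Oc2ccnc3[nH]ccc23)c(F)c1)c1cn(-c2ccc(F)cc2)c2ccccc2c1=O`, 520 nM
compound 2, `O=C(Nc1ccc(Oc2ccnc3[nH]ccc23)c(F)c1)c1cn(-c2ccc(Br)cc2F)c2ccccc2c1=O`, 1390 nM

In a functional assay on MCF7 cells (Homo sapiens) for inhibition, read by MTT assay, with a stated time of 72 h (a higher number here means a weaker inhibitor, a lower number a stronger inhibitor), compound 1 gives 520 nM. In this assay compound 2 gives 1390 nM. Going by the values given here, compound 2 therefore stands at the higher of the two numbers known, with compound 1 as its only neighbour; the one measured step, a 2.7-fold higher number from compound 1 to compound 2 (0.43 log units; beyond the scatter), is modest but beyond the scatter.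

Compound 3, `O=C(Nc1ccc(Oc2ccnc3[nH]ccc23)c(F)c1)c1cn(-c2ccc(C(F)(F)F)cc2Cl)c2ccccc2c1=O`, is not yet measured. It differs from compound 2 in a single place: 2-chloro-4-(trifluoromethyl)phenyl in place of 4-bromo-2-fluorophenyl on an aromatic nitrogen. Among the compounds with values here, the only measured step that bears on this change is a 2.7-fold higher number from compound 1 to compound 2 (0.43 log units; beyond the scatter), where a plain 4-fluorophenyl became a 4-bromo-2-fluorophenyl and the number rose. Compound 3 keeps the same general arrangement of a halogen and a larger group on the aryl ring, so no large further move is anticipated, though a drift toward a somewhat higher number is thought more likely than a return toward compound 1.

On that basis compound 3 is expected to give 1800 nM in this assay, within a range of 700 nM to 4500 nM, corresponding to an estimated step of a 1.3-fold higher number from compound 2 to compound 3 (0.11 log units; within the scatter).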

Compound 3, half-maximal inhibitory concentration: 1120 nM
Compound 3: middle estimate off by 1.6-fold (0.21 log units), on the high side; measured number inside the range.
By their numbers in this assay, from the lowest: compound 1; then compounds 3 and 2 (each within the scatter of the next).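

In this assay, 2-chloro-4-(trifluoromethyl)phenyl in place of 4-bromo-2-fluorophenyl on the aromatic nitrogen gives a 1.2-fold lower number from compound 2 to compound 3 (0.09 log units; within the scatter), so these two differently substituted aryl groups cannot be told apart at this position. Set against the plain 4-fluorophenyl, the same new group gives a 2.2-fold higher number from compound 1 to compound 3 (0.33 log units; beyond the scatter), which means that compound 2 and compound 3 now both stand beyond the scatter on the higher side of compound 1, and the earlier single step gains a second instance with a different pair of substituents. The data shown offer no evidence on why the numbers at this position fall as they do.

Going by these compounds, both steps away from compound 1 alter the aryl group in more than one respect, so it remains open whether the added halogen, the group at the 4-position of the ring, or the two together account for the higher numbers. Also open, on these data alone, is how the assay would respond to an aryl group carrying an amine or a carboxylic acid, or to a simple alkyl chain on the aromatic nitrogen in place of the aryl ring.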